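Replacing the formyl group with an ethoxymethyl group

A few compounds are considered here, and "the series" means these few. Any claim that something is new, unique, unknown or untested is made for them only; others in the source may bear on it.

Measured compounds in a functional assay on DLD-1 cells (Homo sapiens) for cytotoxicity, read by MTT assay, with a stated time of 96 h; on this read-out higher numbers stand for weaker inhibition and lower numbers for stronger inhibition:
compound 1 `O=Cc1cc(Br)c(O)c(O)c1Br` gives 31000 nM
compound 2 `O=Cc1cc(O)c(O)c(Br)c1Br` gives 30900 nM
compound 3 `COCc1cc(Br)c(O)c(O)c1Br` gives 7270 nM

Among these three numbers, compound 2 holds the second highest. Compound 1 gives a number that is indistinguishable from it within the usual scatter, so no order between compound 1 and compound 2 can be read from the data. Compound 3 gives the lowest of the three numbers and is the furthest from compound 2.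

Compound 4 `CCOCc1cc(O)c(O)c(Br)c1Br` differs from compound 2 in a single place: ethoxymethyl in place of formyl on an aromatic carbon. Among the measured compounds shown here, one measured step bears on this change: a 4.3-fold lower number from compound 1 to compound 3 (0.63 log units; beyond the scatter). That step swaps formyl for methoxymethyl; the step to compound 4 swaps formyl for a closely related ethoxymethyl group on a core whose starting number matches that of compound 1. A downward step of similar size is therefore expected, namely a 4.1-fold lower number from compound 2 to compound 4 (0.61 log units; beyond the scatter) in this assay. Compound 4 is estimated at 7500 nM, with a range from 3000 nM to 20000 nM.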

Compound 4, half-maximal inhibitory concentration: 13500 nM
Estimate against measurement, compound 4: 1.8-fold (0.26 log units) below, within the range that was stated.
By their numbers in this assay, from the lowest: compounds 3 and 4 (each within the scatter of the next); then compounds 2 and 1 (each within the scatter of the next).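

In this assay, ethoxymethyl in place of formyl on this aromatic carbon, which is ortho to a bromo group and para to a hydroxy group, gives a 2.3-fold lower number from compound 2 to compound 4 (0.36 log units; beyond the scatter) on the core of compound 2. The earlier compounds shown here showed a downward step only for methoxymethyl on the core of compound 1, as a 4.3-fold lower number from compound 1 to compound 3 (0.63 log units; beyond the scatter) records; the change at this carbon now lowers the number in both pairs, on two different cores. The data offered here give no explanation for either step.

The compounds shown leave open how ethoxymethyl would behave on the core of compound 1 and methoxymethyl on the core of compound 2. They also leave open whether a carboxylic acid, an amine or a longer alkoxymethyl chain at this carbon would move the number further.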